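Replacing the anilide ring in an oxalamide inhibitor

This account rests on a few compounds, and the source may have more. Where it says the series, first, only, none or still open, it means among the compounds named here.

Compound 3, with the structure `O=C(Nc1ccc(Cl)cc1F)C(=O)N1CCC(c2ccnc3ccc(F)cc23)CC1`, sets the reference point for this comparison. In an assay on SK-OV-3 cells for inhibition of Indoleamine 2,3-dioxygenase 1 (Homo sapiens) (on this read-out lower numbers stand for stronger inhibition and higher numbers for weaker inhibition), compound 3 gives 7 nM. Going by the values given here, that is the lowest of the three numbers known so far. The next nearest is compound 1, whose structure is `CS(=O)(=O)NCCCNC(=O)/C(=N/O)Nc1ccc(F)c(Br)c1`; in this assay compound 1 gives 340 nM, a gap beyond the usual scatter. The furthest is compound 2, whose structure is `O=C(/C(=N/O)Nc1ccc(F)c(Cl)c1)N1CCC(c2ccccc2)CC1`; in this assay compound 2 gives 14000 nM, a far wider gap.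

Compound 4, with the structure `O=C(Nc1ccc(C(F)F)cc1)C(=O)N1CCC(c2ccnc3ccc(F)cc23)CC1`, has not yet been measured. It differs from compound 3 in a single place: 4-(difluoromethyl)phenyl in place of 4-chloro-2-fluorophenyl on an amide-type nitrogen. Among the compounds with values here, no pair of measured compounds isolates this particular swap, so there is no measured step to lean on, and the expectation rests on the general picture that the rest of the molecule in compound 3 and compound 4 is the same.

The estimated step of a 2.9-fold higher number from compound 3 to compound 4 (0.46 log units; beyond the scatter) is expected to be a modest move toward a higher number, small enough that it may not clear the scatter. Compound 4 is therefore expected to give about 20 nM in this assay, with a plausible range from 5 nM to 80 nM.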

Compound 4, half-maximal inhibitory concentration: 21 nM
Beside the measured number, compound 4's estimate is 1.1-fold (0.02 log units) below it; the range from low to high includes it.
By their numbers in this assay, from the lowest: compound 3; then compound 4; then compound 1; then compound 2.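

Going by these compounds alone, this is the first measured step that changes only the aromatic ring on the amide-type nitrogen while the rest of the molecule stays the same. In this assay, putting 4-(difluoromethyl)phenyl in place of 4-chloro-2-fluorophenyl gives a 3.0-fold higher number from compound 3 to compound 4 (0.48 log units; beyond the scatter), so the position responds to this swap, but the step is only modest and compound 4 still gives 21 nM, so a ring with no chlorine and no fluorine directly on it can still give a low number here. Nothing measured here explains why the number moves.

The swap removes the chlorine and the ring fluorine and adds the difluoromethyl group all at once, so the compounds shown leave open how much of the step belongs to each of these changes. Also open, on these data alone, is how the number would respond if this position carried a ring with an amine or a carboxylic acid on it, or a pyridine ring in place of the phenyl ring.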